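The source may hold more compounds than are shown below. What is called first, only, known or untested is meant among the compounds shown, and "the series" means these compounds.

Working notes on the series.

Compound 1 `Nc1cccc(-c2cn(CC(=O)Nc3nccs3)nn2)c1` is the reference point. For the measured compounds named here, in a functional assay on BMDM cells (Mus musculus, strain C57BL/6) for inhibition, with a stated time of 2 days (on this read-out lower numbers stand for stronger inhibition and higher numbers for weaker inhibition), compound 1 gives 1270 nM, and this is the only number reported so far in this assay. The remaining entry is a limit rather than a number. Compound 2 `COc1cccc(-c2cn(-c3ccc(C(F)(F)F)cc3)nc2C(=O)N2CCN(c3ncccn3)CC2)c1` reaches only a limit in this assay, > 30000 nM. Going by the values given here, with the limit of > 30000 nM in this assay, at which 1 of the 2 values shown sits, the set holds a single numeric value and one censored entry, so compound 1 carries the whole scale on its own, and no step between measured compounds can be drawn.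

Compound 3 `O=C(Cn1cc(-c2cccc(Cl)c2)nn1)Nc1nccs1` is not yet measured. It differs from compound 1 in one place: chloro in place of amino on an aromatic carbon. The exchange swaps a group with a hydrogen-bond donor and acceptor for one with neither, on an aromatic carbon of a six-membered aromatic ring of carbon only, the rest of the structure being unchanged.

Among the compounds with values here, with no measured step to lean on, the expectation for this assay is a step near the scatter, in no firm direction, from compound 1 to compound 3 of a 1.2-fold higher number from compound 1 to compound 3 (0.07 log units; within the scatter). Compound 3 is estimated at 1500 nM, within 400 nM to 6000 nM.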

Compound 3, half-maximal inhibitory concentration: > 30000 nM
Compound 3: only a limit was reported (the forecaster's own chance of this, stated with the estimate: 10%); at least 20-fold (1.30 log units) between middle value and limit.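

Compound 3 reaches only a limit in this assay, > 30000 nM, which is a limit of the assay and not a number. For the compounds shown here, the exchange of 3-aminophenyl to 3-chlorophenyl is the only step readable, and it gives an at least 23-fold higher number from compound 1 to compound 3 (1.37 log units; beyond the scatter), so a change of one heavy atom at this aromatic carbon is enough to take the core of compound 1 from a measurable value to the end of the scale, which compound 2 alone could not show because it differs from compound 1 in more than one place. The step gives only a minimum size, and the top of the scale now holds most of the set: the limit of > 30000 nM in this assay, at which 2 of the 3 values shown sit.

With only amino and chloro at this place, the compounds shown cannot separate a need for the hydrogen-bond donor and acceptor counted on the amino group from a penalty tied to chloro itself. As far as these compounds go, a hydroxyl group or a methyl group at the same aromatic carbon would bear on that question, and whether any group there gives a lower number than compound 1 remains open.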